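The compounds below may be only part of what the source reports. "The series", "measured", "known", "first", "only" and "open" are said of these compounds alone.

Measured compounds and their values:

- compound 1, `O=[N+]([O-])c1ccccc1CNc1cc(Br)cc2cn[nH]c12`: 35%
- compound 2, `O=[N+]([O-])c1ccc(CNc2cc(C(F)(F)F)cc3[nH]ncc23)cc1`: 47%
- compound 3, `FC(F)(F)c1cc(NC[C@H]2CCCCN2)c2cn[nH]c2c1`: 69%

Three compounds share a core and carry different groups on the nitrogen attached to it. In an assay for inhibition of Tryptophan 2,3-dioxygenase (Homo sapiens), with stated times of 10 min and 60 min, tested at 10 uM (a lower number here means a weaker effect, a higher number a stronger effect of the compound at the concentration tested), compound 1 gives 35%, compound 2 gives 47%, and compound 3 gives 69%. Compound 3 stands highest of the three; its nearest neighbour is compound 2, whose number lies well below it, and compound 1 lies further below still, both gaps beyond the usual scatter of repeated measurements.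

The next compound, compound 4, is `FC(F)(F)c1cc(NC[C@@H]2CCCCN2)c2cn[nH]c2c1`. Compared with compound 3 the change is the two compounds have the same atoms and bonds and differ only in configuration as drawn: 1 of 1 stereo elements differ; a stereocentre at a saturated ring carbon is drawn R in compound 3 and S in compound 4. Among the measured compounds shown here, nothing among the measured compounds shows how a change of configuration alone affects the read-out in this assay, so no step between measured compounds can guide the expectation here. In such cases the two mirror-image forms often differ, and the direction cannot be read from the data at hand. A step of moderate size downward in this assay is expected, as a number 24 percentage points lower from compound 3 to compound 4 (beyond the scatter), with wide uncertainty. For compound 4 the estimated value in this assay is 45%, within a range from 15% to 75%.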

Compound 4, a percentage reported as inhibition, at one concentration (the size of the read-out at that concentration, not a potency): 64%
Compound 4: the middle estimate sits 19 percentage points below what was measured, within the range that was stated.
By their numbers in this assay, from the lowest: compound 1; then compound 2; then compounds 4 and 3 (each within the scatter of the next).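

In this assay, turning the one stereocentre at the saturated ring carbon from R to S gives a number 5 percentage points lower from compound 3 to compound 4 (within the scatter), so this read-out does not tell the two mirror-image forms apart. Among the compounds shown here, this is the first sign that, at this position, the way the ring is drawn in space counts for little at the single concentration tested, whereas the earlier compounds could say nothing about configuration at all. The comparison is a clean one, and the small step can be read directly as the effect of this change alone, because nothing else separates the pair: the fact that compounds 3 and 4 differ only in the configuration as drawn

The compounds shown leave open whether the two forms would stay alike in a true potency measurement, since a percentage at one concentration is not a potency, or once a further group, such as a carboxylic acid or a longer chain, sits on the saturated ring. They also leave open how the read-out of compound 3 and compound 4 would respond if a nitrile took the place of the trifluoromethyl on the shared core.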